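Sulfonyl Substituent Change from Compound 1 to Compound 4

The compounds below may be only part of what the source reports. "The series", "measured", "known", "first", "only" and "open" are said of these compounds alone.

Three measured compounds frame this step. Compound 1 `COc1ccc(S(=O)(=O)/C(=C/c2ccc(C)s2)C(=O)c2ccc(Cl)cc2)cc1` is the reference; in a functional assay on DU-145 cells (Homo sapiens) for inhibition, read by trypan blue exclusion, with a stated time of 96 h (a higher number here means a weaker inhibitor of growth, a lower number a stronger inhibitor of growth), compound 1 gives 25000 nM. Compound 2 `Cc1ccc(S/C(=C/c2c(F)c(F)c(F)c(F)c2F)C(=O)c2ccc(Cl)cc2)cc1` gives 25000 nM in this assay, level with compound 1 at the digits recorded, and together they carry the lowest numbers of the three. Compound 3 `COc1ccc(S/C(=C/c2ccc(C)s2)C(=O)c2ccc(Cl)cc2)cc1` gives 50000 nM in this assay, a higher number than compound 1, though the gap stays within the scatter of the method, so no order between the two can be claimed.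

Compound 4 `Cc1ccc(CS(=O)(=O)/C(=C/c2ccc(C)s2)C(=O)c2ccc(Cl)cc2)cc1` awaits measurement. It differs from compound 1 in a single place: 4-methylbenzyl in place of 4-methoxyphenyl on a sulfonyl sulfur. For the measured compounds named here, no pair of measured compounds that differ in exactly one place is available here, so the size of such a change cannot be read from a measured analogue. What the measured set does show is that all three numbers sit in a narrow band at the weak end, and none of the variation among them moved the value beyond the scatter. The step from compound 1 to compound 4 is expected to be small, with no direction that exceeds the scatter: no change at the digits printed from compound 1 to compound 4 (within the scatter). Compound 4 is estimated at 25000 nM in this assay, with a range from 10000 nM to 60000 nM.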

Compound 4, concentration for 50% growth inhibition: 25000 nM
Estimate against measurement, compound 4: no gap at the digits printed, and the stated range covers the measured number.
By their numbers in this assay, from the lowest: compounds 1, 2, 4 and 3 (each within the scatter of the next).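

For the compounds shown here, the exchange of 4-methoxyphenyl for 4-methylbenzyl on a sulfonyl sulfur gives the only one-place step available in this assay: no change at the digits printed from compound 1 to compound 4 (within the scatter). Going by these compounds alone, this is the first direct reading at this position, and it shows that a group with 1 hydrogen-bond acceptor can give way to one with 0 hydrogen-bond acceptors, at 8 heavy atoms and one six-membered aromatic ring in both groups, without the number leaving the scatter. No measurement on hand accounts for this flat result.

Going by these compounds, it remains open whether a group of another kind on the sulfonyl sulfur, such as an amine, a carboxylic acid or a longer chain, would shift the number beyond the scatter in this assay. A single step also cannot say whether the same exchange would stay as flat on a core carrying different groups elsewhere.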